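The compounds below may be only part of what the source reports. "The series", "measured", "known", "first", "only" and "open" are said of these compounds alone.

Compound 1 `CS(=O)(=O)c1cc(C(=O)N=C(N)N)ccc1Oc1cccnc1` gives 76 nM in a functional assay for inhibition of sodium/hydrogen exchanger (Oryctolagus cuniculus); a higher number here means a weaker inhibitor, a lower number a stronger inhibitor. Compound 2 `CS(=O)(=O)c1cc(C(=O)N=C(N)N)ccc1Cl` gives 380 nM in this assay, and the step of a 5.0-fold higher number from compound 1 to compound 2 (0.70 log units; beyond the scatter) separates the two. Going by the values given here, compound 2 thus stands at the highest of the two numbers measured, with compound 1 as its only neighbour.

Compound 3 `CS(=O)(=O)c1cc(C(=O)N=C(N)N)ccc1Oc1cncc(Cl)c1` differs from compound 2 by (5-chloropyridin-3-yl)oxy in place of chloro on an aromatic carbon, on the aromatic carbon ortho to the methylsulfonyl group. Among the compounds with values here, the only measured step that bears on this change is the one from compound 1 to compound 2, which went in the opposite direction with a modest size; compound 3 carries the aryloxy group again, now with a chloro on the pyridine ring, for which no measured comparison exists.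

On that basis a step downward of about the size of a 5.0-fold higher number from compound 1 to compound 2 (0.70 log units; beyond the scatter) is expected, giving a 4.8-fold lower number from compound 2 to compound 3 (0.68 log units; beyond the scatter), and compound 3 is estimated at 80 nM in this assay, within 25 nM to 250 nM.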

Compound 3, half-maximal inhibitory concentration: 75 nM
Compound 3: the middle estimate sits 1.1-fold (0.03 log units) above what was measured; the range from low to high includes it.
By their numbers in this assay, from the lowest: compounds 3 and 1 (each within the scatter of the next); then compound 2.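

In this assay, (5-chloropyridin-3-yl)oxy in place of chloro, ortho to the methylsulfonyl group, gives a 5.1-fold lower number from compound 2 to compound 3 (0.70 log units; beyond the scatter), so a second aryloxy group now stands apart from compound 2, as compound 1 already did. Chloro in place of hydrogen on the pyridine ring of the aryloxy group gives a 1.0-fold lower number from compound 1 to compound 3 (0.01 log units; within the scatter), so this ring takes a chloro with no readable difference in the number. No data at hand offer a reason for either step.

On these data alone, whether an amine or a methoxy group at the same place would read like the aryloxy groups or like chloro remains open. Also open, as far as these compounds go, is whether a larger or charged group on the pyridine ring, such as a carboxylic acid or a dimethylamino group, would be tolerated as chloro is.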